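Adding a benzyloxycarbonyl group to an inactive quinolinone series

A few compounds are considered here, and "the series" means these few. Any claim that something is new, unique, unknown or untested is made for them only; others in the source may bear on it.

Measured compounds and their values:
- compound 1, `COc1cccc2cc(-c3ccccc3)c(O)nc12`: 10000 nM
- compound 2, `COc1cc(OC)c2cc(-c3ccc(OCc4ccccc4)cc3)c(O)nc2c1`: 10000 nM
- compound 3, `COc1ccc(-c2cc3c(OC)cc(OC)cc3n(C)c2=O)cc1`: 10000 nM

In a functional assay on J82 cells (Homo sapiens) for cytotoxicity, read by colorimetric assay and MTT assay (a lower number here means a stronger inhibitor, a higher number a weaker inhibitor), compound 1 gives 10000 nM, compound 2 gives 10000 nM and compound 3 gives 10000 nM. All three numbers are the same at the digits shown, so compound 3 stands level with compound 1 and compound 2, and none of the three can be called stronger or weaker than another. The shared core carries different substituents in each, yet the read-out does not move.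

The next compound, compound 4, `COc1ccc(-c2cc3c(OC)cc(OC)cc3n(CC(=O)OCc3ccccc3)c2=O)cc1`, is not yet measured. It differs from compound 3 in one place: benzyloxycarbonyl in place of hydrogen on a saturated chain carbon bound to an aromatic nitrogen. Cut one bond further out, the same change reads methyl to (benzyloxycarbonyl)methyl.

Among the measured compounds shown here, no measured pair in this set differs in a single place, so there is no measured step to lean on. For the measured compounds named here, with every compound so far at the same value, the expectation is for a step from compound 3 to compound 4 of none beyond the scatter, in either direction, no change at the digits printed from compound 3 to compound 4 (within the scatter). The estimate for compound 4 in this assay is therefore 10000 nM, expected to fall between 4000 nM and 25000 nM.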

Compound 4, half-maximal inhibitory concentration: 10000 nM
Compound 4: middle estimate and measured number agree at the digits printed; the measured number falls inside the stated range.
By their numbers in this assay, from the lowest: compounds 1, 2, 3 and 4 (each within the scatter of the next).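

Among the compounds shown here, compound 3 and compound 4 differ in one place, which gives the first direct reading of a single change in this set: the step reads no change at the digits printed from compound 3 to compound 4 (within the scatter) in this assay when benzyloxycarbonyl replaces hydrogen on a saturated chain carbon bound to an aromatic nitrogen. The entering group brings 10 heavy atoms and an aromatic ring of its own, yet at this position the read-out does not move in either direction, so even an addition of this size leaves the number where it was. Nothing measured here offers an explanation for this flat result.

From the compounds shown here alone, it remains open whether any other group at this position would shift the number, for example a carboxylic acid in place of the benzyloxycarbonyl, or an amine at the end of a longer chain. With all four compounds level, the set also gives no sign of which part of the shared core, if any, the read-out depends on.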